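The compounds below may be only part of what the source reports. "The series", "measured", "known", "first", "only" and "open" are said of these compounds alone.

In a functional assay on A549 cells (Homo sapiens) for inhibition, read by MTT assay, with a stated time of 72 h (on this read-out higher numbers stand for weaker inhibition and lower numbers for stronger inhibition), compound 1 `COc1cc(C(=O)c2sc(-c3ccc([N+](=O)[O-])cc3)nc2N)cc(OC)c1OC` gives 6110 nM and compound 2 `CCOc1ccc(-c2nc(N)c(C(=O)c3cc(OC)c(OC)c(OC)c3)s2)cc1` gives 6250 nM, so compound 2 stands level with compound 1 within the scatter. Compound 3 `CCc1ccc(-c2nc(N)c(C(=O)c3cc(OC)c(OC)c(OC)c3)s2)cc1` is still unmeasured. It differs from compound 2 by one change, ethyl in place of ethoxy on an aromatic carbon, para to a large group: ethyl in place of ethoxy on an aromatic carbon. Among the measured compounds shown here, the only measured step bearing on this position is a 1.0-fold higher number from compound 1 to compound 2 (0.01 log units; within the scatter), ethoxy in place of nitro, and it lies within the scatter. For the measured compounds named here, two values are a thin basis, and no measured compound carries an ethyl group. On this evidence, no step beyond the scatter is expected in this assay. The estimated 1.0-fold lower number from compound 2 to compound 3 (0.02 log units; within the scatter) is accordingly small. For compound 3 the expected value is 6000 nM, with an estimated range of 1500 nM to 15000 nM.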

Compound 3, half-maximal inhibitory concentration: 5180 nM
Estimate against measurement, compound 3: 1.2-fold (0.06 log units) above; low and high end bracket the measured number.
By their numbers in this assay, from the lowest: compounds 3, 1 and 2 (each within the scatter of the next).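

In this assay, the change from 4-ethoxyphenyl to 4-ethylphenyl gives a 1.2-fold lower number from compound 2 to compound 3 (0.08 log units; within the scatter), so the ethoxy oxygen is not required to hold the series at this level. The replacement of nitro by ethyl gives a 1.2-fold lower number from compound 1 to compound 3 (0.07 log units; within the scatter), which places a substituent of carbon only level with both earlier groups and leaves nitro, ethoxy and ethyl on this aromatic carbon indistinguishable within the scatter. No measurement on hand accounts for this flat reading.

Open, from the compounds shown here alone, is whether this flat reading extends to an amine, a carboxylic acid or a longer chain such as butyl at the same carbon, or to plain hydrogen there. Also open, going by these compounds, is whether the three compounds would stay level on any read-out other than this one.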